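Heteroaryl ring enters at the carbonyl carbon of compound 3

This account rests on a few compounds, and the source may have more. Where it says the series, first, only, none or still open, it means among the compounds named here.

Compound 1, `Cc1nc(S(C)(=O)=O)ccc1Oc1ncnc(OC2CCN(C(=O)OC3CCC3)CC2)c1F`, gives 13.6 nM in a functional assay on isolated protein for inhibition of Glucose-dependent insulinotropic receptor (Homo sapiens), read by HTRF and cAMP accumulation; a higher number here means that more compound is needed for the effect, a lower number that less compound is needed.
Compound 2, `Cc1nc(S(C)(=O)=O)ccc1Oc1ncnc(OC2CCN(C(=O)OC3(C(F)(F)F)COC3)CC2)c1F`, gives 29.3 nM in this assay.
Compound 3, `Cc1nc(S(C)(=O)=O)ccc1Oc1ncnc(OC2CCN(C(=O)SC3CCC3)CC2)c1F`, gives 8.51 nM in this assay.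

Compound 3 holds the lowest of the three numbers in this assay. Its distance from compound 1 is small, since a 1.6-fold lower number from compound 1 to compound 3 (0.20 log units; within the scatter) is within the scatter, while the larger gap, a 3.4-fold lower number from compound 2 to compound 3 (0.54 log units; beyond the scatter), lies beyond it. The remaining step, a 2.2-fold higher number from compound 1 to compound 2 (0.33 log units; beyond the scatter), is also modest.

Compound 4, `Cc1nc(S(C)(=O)=O)ccc1Oc1ncnc(OC2CCN(C(=O)c3ncc(Cl)cn3)CC2)c1F`, differs from compound 3 in one place: 5-chloropyrimidin-2-yl in place of cyclobutylsulfanyl on a carbonyl carbon. Among the measured compounds shown here, no measured step brings a 5-chloropyrimidin-2-yl onto the carbonyl carbon, so the guide is indirect. The two steps that change the group on the carbonyl carbon, a 1.6-fold lower number from compound 1 to compound 3 (0.20 log units; within the scatter) and a 3.4-fold lower number from compound 2 to compound 3 (0.54 log units; beyond the scatter), stayed modest in size, and a 2.2-fold higher number from compound 1 to compound 2 (0.33 log units; beyond the scatter) did too. A modest step is therefore expected for compound 4 as well, a 1.9-fold higher number from compound 3 to compound 4 (0.27 log units; within the scatter), with the direction uncertain and a somewhat higher number judged more likely since compound 3 already has the lowest number. Compound 4 is estimated at 16 nM, within 4 nM to 60 nM.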

Compound 4, half-maximal effective concentration: 6.12 nM
Beside the measured number, compound 4's estimate is 2.6-fold (0.42 log units) above it, within the range that was stated.
By their numbers in this assay, from the lowest: compounds 4, 3 and 1 (each within the scatter of the next, the first and the last beyond it); then compound 2.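

At the carbonyl carbon, an aromatic ring attached directly, 5-chloropyrimidin-2-yl, can take the place of cyclobutylsulfanyl with no change beyond the scatter in this assay, as a 1.4-fold lower number from compound 3 to compound 4 (0.14 log units; within the scatter) shows. The same ring also compares well with the two groups attached through oxygen, giving a 2.2-fold lower number from compound 1 to compound 4 (0.35 log units; beyond the scatter) and a 4.8-fold lower number from compound 2 to compound 4 (0.68 log units; beyond the scatter), so among these four compounds this position accepts both the non-aromatic rings and an aromatic one with no rise in the number. Nothing measured here on these compounds accounts for this tolerance.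

The compounds shown leave open whether the chlorine or the ring nitrogens matter to this result, which a phenyl ring or a pyrimidine ring without the chlorine at the carbonyl carbon would test. They also leave open how a secondary amine attached at that carbon would compare.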